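Bromo for iodo on the chain carbon of compound 3

The source may report more compounds than this note shows. Statements on the series, on what has been measured and on what is new or still open speak of the compounds shown alone.

Of the compounds shown here, three have been measured in a functional assay on the whole organism for inhibition, with Mus musculus as the target, at a dose of 10 mg/kg; a lower number here means less inhibition, a higher number more inhibition at the dose given (going by the name of the read-out). Compound 3 `O=C1C(CI)=CS(=O)(=O)c2ccccc21` gives 98% and stands second highest of the three numbers. Its nearest neighbour is compound 1 `O=C1C(COCCBr)=CS(=O)(=O)c2ccccc21`, which in this assay gives 100%; the step of a number 2 percentage points lower from compound 1 to compound 3 (within the scatter) lies within the scatter, so the two are not distinguishable. The furthest is compound 2 `O=C1C(CNc2ccccc2)=CS(=O)(=O)c2ccccc21`, which gives 0%, and the step of a number 98 percentage points higher from compound 2 to compound 3 (beyond the scatter) is large and beyond the scatter.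

Compound 4 `O=C1C(CBr)=CS(=O)(=O)c2ccccc21` is not yet measured. Relative to compound 3 it differs as bromo in place of iodo on a saturated chain carbon bound to a double-bonded ring carbon. Among the compounds with values here, two measured steps touch the same place on the saturated chain carbon: a number 2 percentage points lower from compound 1 to compound 3 (within the scatter) shows that iodo and 2-bromoethoxy give the same read-out within the scatter, while a number 98 percentage points higher from compound 2 to compound 3 (beyond the scatter) shows that anilino at this place removes the inhibition. No halogen-to-halogen exchange has been measured, but bromo is the nearer of the two comparisons to iodo.

Compound 4 is therefore expected to stay near the top of the series, with a step of a number 3 percentage points lower from compound 3 to compound 4 (within the scatter) that should fall within the scatter. For compound 4 the estimate in this assay is 95%, with a range from 80% to 100%.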

Compound 4, a percentage reported as inhibition, in the whole organism at one dose (the size of the read-out at that dose, not a potency): 92.8%
Compound 4: middle estimate off by 2.2 percentage points, on the high side; low and high end bracket the measured number.
By their numbers in this assay, from the lowest: compound 2; then compounds 4, 3 and 1 (each within the scatter of the next).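

In this assay, the exchange of one halogen for another on a saturated chain carbon bound to a double-bonded ring carbon gives a number 5.2 percentage points lower from compound 3 to compound 4 (within the scatter), so iodo and bromo cannot be told apart at this place. Within the data shown here, the 2-bromoethoxy group cannot be separated from bromo either, with a number 7.2 percentage points lower from compound 1 to compound 4 (within the scatter), while anilino remains apart, with a number 92.8 percentage points higher from compound 2 to compound 4 (beyond the scatter); compound 1, compound 3 and compound 4 therefore form one group in this read-out, and compound 2 is the one compound that goes against it. No available evidence bears on what separates compound 2 from the other three.

Open, going by these compounds, is whether other groups at this place, such as chloro, hydroxy, methoxy or a plain amine such as dimethylamino, would join compound 1, compound 3 and compound 4 or fall with compound 2. On these data alone, open too, with a read-out taken at a single dose, is whether compound 1, compound 3 and compound 4 would separate at a lower dose.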